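Compound 3: 3-aminoazetidin-1-yl in place of 3-hydroxyazetidin-1-yl

A few compounds are considered here, and "the series" means these few. Any claim that something is new, unique, unknown or untested is made for them only; others in the source may bear on it.

In an ADME assay for permeability, using PAMPA, with a stated time of 4 h (a higher number here means that the compound crosses the layer faster, a lower number that the compound crosses the layer more slowly), compound 1 (`CN1CCNC(=O)COc2ccc(F)cc2C(=O)N2CCCC[C@H]2c2cc3nc(N4CCC4)cc1n3n2`) gives 80 10^-6 cm/s and compound 2 (`CN1CCNC(=O)COc2ccc(F)cc2C(=O)N2CCCC[C@H]2c2cc3nc(N4CC(O)C4)cc1n3n2`) gives 8 10^-6 cm/s as the lowest of the two numbers. Compound 3 (`CN1CCNC(=O)COc2ccc(F)cc2C(=O)N2CCCC[C@H]2c2cc3nc(N4CC(N)C4)cc1n3n2`) is still unmeasured. The change from compound 2 to compound 3 (amino in place of hydroxy on a saturated ring carbon) is amino in place of hydroxy on a saturated ring carbon. Within the data shown here, one measured step bears on it, at that same ring carbon: a 10-fold lower number from compound 1 to compound 2 (1.00 log units; beyond the scatter) with hydroxy in place of hydrogen. Among the measured compounds shown here, no measured step covers the exchange of hydroxy for amino itself, so that single step is a thin guide to direction. A smaller further fall is expected in this assay and is estimated as a 2.7-fold lower number from compound 2 to compound 3 (0.43 log units; beyond the scatter) for this exchange. Compound 3 is estimated at 3 10^-6 cm/s with an expected range from 0.7 10^-6 cm/s to 10 10^-6 cm/s in this assay.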

Compound 3, apparent permeability: 3.3 10^-6 cm/s
For compound 3 the middle estimate is 1.1-fold (0.04 log units) below the measured one; low and high end bracket the measured number.
By their numbers in this assay, from the lowest: compound 3; then compound 2; then compound 1.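

In this assay this saturated ring carbon distinguishes between two substituents of one heavy atom each: amino in place of hydroxy brings a 2.4-fold lower number from compound 2 to compound 3 (0.38 log units; beyond the scatter) even though the counts of hydrogen-bond donors and acceptors stay the same. Measured from hydrogen at this carbon, amino gives a 24-fold lower number from compound 1 to compound 3 (1.38 log units; beyond the scatter) and so stands further from compound 1 than hydroxy, which gives a 10-fold lower number from compound 1 to compound 2 (1.00 log units; beyond the scatter) in the same direction. Nothing at hand accounts for the gap between the two groups.

Open, from the compounds shown here alone, is whether a methylamino or dimethylamino group at this carbon would follow amino, and where a carboxylic acid would fall. Also open, going by these compounds, is whether a longer chain such as aminomethyl or hydroxymethyl would keep the same order.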